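The source may report more compounds than this note shows. Statements on the series, on what has been measured and on what is new or still open speak of the compounds shown alone.

The measured compounds in a functional assay (plasma) for inhibition, with Homo sapiens as the target; a lower number here means a stronger inhibitor, a higher number a weaker inhibitor:

compound 1, `O=C(O)CCC/C=C\C[C@H]1/C(=N/OC(c2ccccc2)c2ccccc2)CC[C@@H]1NS(=O)(=O)c1ccc(F)cc1`, gives 17000 nM
compound 2, `Cc1ccc(S(=O)(=O)N[C@H]2CC/C(=N\OC(c3ccccc3)c3ccccc3)[C@@H]2C/C=C\CCCC(=O)O)cc1`, gives 5600 nM
compound 3, `Cc1ccc(S(=O)(=O)N[C@H]2CC/C(=N\OCC3CCCCC3)[C@@H]2C/C=C\CCCC(=O)O)cc1`, gives 600 nM

Compounds 2 and 1 share a core and differ in one place: fluoro in place of methyl on an aromatic carbon. That change brought a 3.0-fold higher number from compound 2 to compound 1 (0.48 log units; beyond the scatter). Compound 3 carries a different core from compound 2; the difference between the two cores is not broken down here, but the two values show compound 3 with the lowest number of the three, with compound 2 nearest and compound 1 furthest.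

Compound 4, `O=C(O)CCC/C=C\C[C@H]1/C(=N/OCC2CCCCC2)CC[C@@H]1NS(=O)(=O)c1ccc(F)cc1`, remains to be measured in this assay. It differs from compound 3 in one place: fluoro in place of methyl on an aromatic carbon. The surroundings of the change read the same way as for compounds 2 and 1, so this is the same change, made on the core of compound 3 instead of that of compound 2.

Going by the values given here, the step from compound 3 to compound 4 is expected to be a 3.0-fold higher number from compound 3 to compound 4 (0.48 log units; beyond the scatter), because the one measured instance of this change gave a 3.0-fold higher number from compound 2 to compound 1 (0.48 log units; beyond the scatter) on the other core, and there is only that one instance to go on. For compound 4, then, the estimate is 1800 nM, with a range from 900 nM to 4000 nM.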

Compound 4, half-maximal inhibitory concentration: 1800 nM
Estimate against measurement, compound 4: no gap at the digits printed; the measured number falls inside the stated range.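

In this assay, putting 4-fluorophenyl in place of 4-methylphenyl on the second core gave a 3.0-fold higher number from compound 3 to compound 4 (0.48 log units; beyond the scatter), a step in the same direction as the one seen on the first core. The two steps match in size, so in this series the change carried over from one core to the other with its effect intact: the same change on two cores in this assay, a 3.0-fold higher number (0.48 log units; beyond the scatter) from compound 2 to compound 1 and a 3.0-fold higher number (0.48 log units; beyond the scatter) from compound 3 to compound 4, 1.0-fold (0.01 log units) apart, within the scatter of two such steps

This agreement rests on just two cores, so it does not show that the step would keep its size on a further core, and it does not explain why the change raises the number.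

The compounds shown leave open how a chloro, a methoxy or a plain hydrogen in the same place on the aromatic ring would compare with methyl and fluoro. They also leave open whether the step would hold on a core with a shorter carboxylic acid chain, or with an amide in place of the sulfonamide.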